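The source may hold more compounds than are shown below. What is called first, only, known or untested is meant among the compounds shown, and "the series" means these compounds.

Compound 1 `Cc1cc(C(F)(F)F)cc(NC[C@@H]2CC3(CC3)CN2C(=O)c2nc(C)sc2-c2ccccc2)n1` is the stronger of the two compounds for which a number exists in a functional assay on HEK293 cells for antagonist activity at Orexin receptor type 2 (Homo sapiens), read by FLIPR and calcium flux; a lower number here means a less potent compound, a higher number a more potent compound, by a factor of ten per unit of this negative logarithm. In this assay, among the measured compounds shown here, compound 1 gives 8.6, the highest of the numbers so far. For the measured compounds named here, the only other measured compound, compound 2 `O=C(c1ncccc1-c1ncccn1)N1CC2(CC2)C[C@H]1CNc1ccc(C(F)(F)F)cn1`, keeps the shared core but carries a different acyl group and a different aryl amine, so no single change separates the two. In this assay compound 2 gives 5, a number far beneath that of compound 1 and well beyond the scatter of the assay.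

The next compound, compound 3 `Cc1ccnc(NC[C@@H]2CC3(CC3)CN2C(=O)c2nc(C)sc2-c2ccccc2)n1`, is still to be measured. It differs from compound 1 in one place only: 4-methylpyrimidin-2-yl in place of 6-methyl-4-(trifluoromethyl)pyridin-2-yl on an amine nitrogen. The trifluoromethyl group of compound 1 is lost along with the pyridine nitrogen arrangement, and a second ring nitrogen arrives instead. Going by the values given here, no measured pair isolates this exchange, so the size of the step rests on judgement alone. A modest loss is expected, a step of a number 0.80 log units lower from compound 1 to compound 3 (beyond the scatter). Compound 3 is accordingly estimated at 7.8, with a range from 7 to 8.5, pending the result.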

Compound 3, negative logarithm of the antagonist equilibrium constant: 7
Compound 3: the middle estimate sits 0.80 log units above what was measured; measured number inside the range.
By their numbers in this assay, from the lowest: compound 2; then compound 3; then compound 1.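

The aryl group on this amine nitrogen proves to weigh heavily in this assay: with the rest of compound 1 unchanged, 4-methylpyrimidin-2-yl in place of 6-methyl-4-(trifluoromethyl)pyridin-2-yl gives a number 1.60 log units lower from compound 1 to compound 3 (beyond the scatter). The earlier pair could not show this, since compound 1 and compound 2 differ in both the acyl group and the aryl amine, and no part of their gap could be assigned to either place. The exchange removes the trifluoromethyl group and adds a second ring nitrogen in a single step, and no measurement here accounts for the drop in potency.

From the compounds shown here alone, what remains open is how much of the step belongs to the trifluoromethyl group and how much to the change of ring, and a pyrimidine ring carrying trifluoromethyl or a pyridine ring carrying only methyl on this amine nitrogen would begin to separate the two. Also unsettled is whether another substituent, such as chlorine or a nitrile in place of trifluoromethyl, would hold the potency of compound 1 in this assay.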